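Shortening the side chain on compound 1

This account rests on a few compounds, and the source may have more. Where it says the series, first, only, none or still open, it means among the compounds named here.

Compound 1: `CC(Sc1nc2c(cnn2C)c(=O)n1-c1ccc(CCO)cc1)c1ccccc1`, 3000 nM
Compound 2: `CC(C)C(Sc1nc2c(cnn2C)c(=O)n1-c1ccccc1)c1ccccc1`, 130 nM

Of the two measured compounds, compound 1 has the higher number in an assay on isolated protein for inhibition of Retinaldehyde dehydrogenase 3 (Homo sapiens) (on this read-out lower numbers stand for stronger inhibition and higher numbers for weaker inhibition), and compound 2 gives the lower number by a margin beyond the usual scatter. Compound 3, `CC(Sc1nc2c(cnn2C)c(=O)n1-c1ccc(CO)cc1)c1ccccc1`, differs from compound 1 only by hydroxy in place of hydroxymethyl on a saturated chain carbon bound to an aromatic carbon. For the measured compounds named here, with no comparable measured pair to lean on, the step from compound 1 to compound 3 is expected to be small, no change at the digits printed from compound 1 to compound 3 (within the scatter), and not beyond the scatter in either direction. For compound 3, the expected result in this assay is 3000 nM, within a range from 1000 nM to 9000 nM.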

Compound 3, half-maximal inhibitory concentration: 1000 nM
For compound 3 the middle estimate is 3.0-fold (0.48 log units) above the measured one; the range from low to high includes it.
By their numbers in this assay, from the lowest: compound 2; then compound 3; then compound 1.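

In this assay the change from 2-hydroxyethyl to hydroxymethyl gives a 3.0-fold lower number from compound 1 to compound 3 (0.48 log units; beyond the scatter) and so shows that this position responds to the loss of a single chain carbon. The hydroxy end is present in both compounds, so this step reads chain length alone. Nothing measured here explains why the shorter chain gives the lower number.

As far as these compounds go, whether the direction continues with a longer chain such as 3-hydroxypropyl remains open. So does whether the hydroxy end matters, which an aminomethyl group or a carboxylic acid at this position could help to test.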